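Anilino-substituted tricyclic quinone series: estimate for 3-fluorophenyl analogue

This account rests on a few compounds, and the source may have more. Where it says the series, first, only, none or still open, it means among the compounds named here.

Measured so far in a functional assay on HeLa cells (Homo sapiens) for inhibition, read by sulforhodamine B assay; on this read-out lower numbers stand for stronger inhibition and higher numbers for weaker inhibition:
- compound 1 `CCCc1ccc(NC2=CC(=O)c3c(nc4n3[C@H]3OC[C@@H](O)[C@H]3OC4)C2=O)cc1`: 6030 nM
- compound 2 `CCOc1ccccc1NC1=CC(=O)c2nc3n(c2C1=O)[C@H]1OC[C@@H](O)[C@H]1OC3`: 6040 nM
- compound 3 `O=C1C=C(N2CCCCC2)C(=O)c2c1nc1n2[C@H]2OC[C@@H](O)[C@H]2OC1`: > 16000 nM (a limit of the assay)

Compound 1 holds the lowest of the two numbers available in this assay; compound 2 lies at practically the same number, so the two fall within the scatter and no order is claimed between them. For compound 3 the assay gives only a limit (the limit of > 16000 nM in this assay, at which 1 of the 3 values shown sits), not a number.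

Compound 4 `O=C1C(Nc2cccc(F)c2)=CC(=O)c2c1nc1n2[C@H]2OC[C@@H](O)[C@H]2OC1` differs from compound 1 in one place: 3-fluorophenyl in place of 4-propylphenyl on an amine nitrogen. Among the measured compounds shown here, no measured step of this kind exists here. A small rise in the number for compound 4 relative to compound 1 is expected, at the edge of the scatter, so compound 4 is estimated at 8000 nM, likely between 3000 nM and 20000 nM, meaning a step of a 1.3-fold higher number from compound 1 to compound 4 (0.12 log units; within the scatter) in this assay.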

Compound 4, half-maximal inhibitory concentration: > 8000 nM
Compound 4: a limit, no number (the forecaster's own chance of this, stated with the estimate: 25%); the middle value sits exactly at the limit.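

In this assay compound 4 gives > 8000 nM, a limit and not a number. Among the compounds shown here, exchanging 4-propylphenyl for 3-fluorophenyl on the amine nitrogen gives the first readable step at this place: an at least 1.3-fold higher number from compound 1 to compound 4 (0.12 log units; that floor lies within the scatter). As far as these compounds go, this step is only a floor, so the exchange brings no lower number, but its true size remains unknown.

From the compounds shown here alone, how far compound 4 lies past its limit stays open. Also open, going by these compounds, is what a plain phenyl or a 4-fluorophenyl on the same nitrogen would give, and so whether the fluorine or the loss of the propyl chain accounts for the step.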